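Swapping the chloro of compound 1 for hydrogen

The compounds below may be only part of what the source reports. "The series", "measured", "known", "first", "only" and "open" are said of these compounds alone.

Compound 1 `Cc1cccc(Nc2nc(NC3CCCCC3N)c(Cl)c3cn[nH]c(=O)c23)c1` is the compound this step begins from. In an ADME assay on BaF3 cells (Mus musculus) for inhibition, read by luminescence and CellTiter-Glo, with a stated time of 3 days (a higher number here means a weaker inhibitor of growth, a lower number a stronger inhibitor of growth), compound 1 gives 1500 nM. In this assay compound 2 `Cc1cccc(Nc2nc(NC3CCCCC3N)cc3cc[nH]c(=O)c23)c1` gives 1920 nM, and these two numbers lie within the usual scatter of each other, so they cannot be told apart. In this assay compound 3 `N#Cc1cc2c(N)cn(Cc3ccccc3)c2nc1NC1CCCCC1N` has no number, only a limit of > 5000 nM.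

Compound 4 `Cc1cccc(Nc2nc(NC3CCCCC3N)cc3cn[nH]c(=O)c23)c1` has not been measured yet. It differs from compound 1 in one place: hydrogen in place of chloro on an aromatic carbon. Hydrogen takes the place of chloro on an aromatic carbon, ortho to a (2-aminocyclohexyl)amino group and para to a (3-methylphenyl)amino group.

Within the data shown here, no two measured compounds differ by this change alone, so its size cannot be read directly from the data. The expectation in this assay is therefore no step beyond the scatter, in either direction, though with a wide margin. It rests on the numbers closest to hand, compound 1 at 1500 nM and compound 2 at 1920 nM. The expected change is small, as a 1.1-fold higher number from compound 1 to compound 4 (0.03 log units; within the scatter) shows. Compound 4 is estimated at 1600 nM, with an expected range from 550 nM to 4500 nM.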

Compound 4, concentration for 50% growth inhibition: 1500 nM
Estimate against measurement, compound 4: 1.1-fold (0.03 log units) above, within the range that was stated.
By their numbers in this assay, from the lowest: compounds 1, 4 and 2 (each within the scatter of the next). At a limit, above all of these: compound 3.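

Replacing the chloro with hydrogen on this aromatic carbon, ortho to a (2-aminocyclohexyl)amino group and para to a (3-methylphenyl)amino group, gives in this assay no change at the digits printed from compound 1 to compound 4 (within the scatter). Among these compounds, this is the first direct reading of the change, as no earlier pair of compounds isolated this position, and it shows that in this assay the chloro can be removed without a change that can be told from the scatter. The data shown offer no measurement that would explain this result.

Chloro and hydrogen are the only two groups seen at this position, so it remains open whether a methoxy group, a carboxylic acid or a longer alkyl chain in the same place would shift the number beyond the scatter or leave it as flat as this step did. Among the compounds shown here, also open is whether the same swap would read the same way on a core other than that of compound 1, as this single pair is the only reading of it so far.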